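This account rests on a few compounds, and the source may have more. Where it says the series, first, only, none or still open, it means among the compounds named here.

Measured compounds:
Compound 1, `COc1cc(Nc2nc3ccccc3nc2S(=O)(=O)c2ccccc2)cc(OC)c1`: in a functional assay on HL-60 cells (Homo sapiens) for cytotoxicity, read by MTT assay, with a stated time of 72 h (a higher number here means a weaker inhibitor, a lower number a stronger inhibitor), compound 1 gives 50 nM.
Compound 2, `O=S(=O)(c1ccccc1)c1nc2ccccc2nc1Nc1ccc(Cl)cc1`: in this assay compound 2 gives 1920 nM.

Going by the values given here, compound 1 holds the lowest of the two numbers; the one step that connects them, a 38-fold higher number from compound 1 to compound 2 (1.58 log units; beyond the scatter), shows how much the aryl group on the ring nitrogen can matter. Compound 3, `COc1cc(Nc2nc3ccccc3nc2S(=O)(=O)c2ccc(Br)cc2)cc(OC)c1`, keeps the 3,5-dimethoxyphenyl group of compound 1 untouched and differs only by bromo in place of hydrogen on an aromatic carbon, so that the phenylsulfonyl becomes a (4-bromophenyl)sulfonyl. Among the compounds with values here, no measured step touches that ring; the sole step in hand concerns the other aryl group and therefore bears only loosely on this change. With nothing to point either way, no step beyond the scatter is expected in this assay for compound 3, which is estimated at 50 nM, within 15 nM to 200 nM. That estimate means an expected step of no change at the digits printed from compound 1 to compound 3 (within the scatter).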

Compound 3, half-maximal inhibitory concentration: 2540 nM
Compound 3: the middle estimate sits 51-fold (1.71 log units) below what was measured; the measured number lies above the stated range.
By their numbers in this assay, from the lowest: compound 1; then compounds 2 and 3 (each within the scatter of the next).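

In this assay, the ring on the sulfonyl proves sensitive to change: with the 3,5-dimethoxyphenyl group left in place, a single bromo on an aromatic carbon, para to a large group, gives a 51-fold higher number from compound 1 to compound 3 (1.71 log units; beyond the scatter). Until now, only a change to the aryl group on the nitrogen had shown a large step, a 38-fold higher number from compound 1 to compound 2 (1.58 log units; beyond the scatter), so the potency of compound 1 now depends on both aryl groups, at least for these two changes. No evidence is available on the reason for this step.

The compounds shown leave open whether the step is specific to bromo or would also appear with fluoro, methoxy or an amine at the same carbon. They also leave open how bromo would behave on another carbon of that ring.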